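Trifluoromethyl enters the oxadiazole of a dipropylamino amide

The source may hold more compounds than are shown below. What is called first, only, known or untested is meant among the compounds shown, and "the series" means these compounds.

In an assay on Jurkat E6.1 cells for inhibition of histone deacetylase 4 (Homo sapiens), read by fluorescence (on this read-out lower numbers stand for stronger inhibition and higher numbers for weaker inhibition), compound 2 `CCCN(CCC)C[C@@H](C)NC(=O)c1ccc(-c2ncon2)cc1` reaches only the limit of the assay, at > 50000 nM (the limit of > 50000 nM in this assay, at which 1 of the 3 values shown sits). Compound 4 `CCCN(CCC)C[C@@H](C)NC(=O)c1ccc(-c2nc(C(F)(F)F)no2)cc1` is the unmeasured analogue: it carries 3-(trifluoromethyl)-1,2,4-oxadiazol-5-yl in place of 1,2,4-oxadiazol-3-yl on an aromatic carbon. Among the measured compounds shown here, no measured pair differs in this single place, so the step has no direct precedent. Two related amides with a trifluoromethyl on the oxadiazole are measured: compound 1 `CC(C)(CN1CCCC1)NC(=O)c1ccc(-c2noc(C(F)(F)F)n2)cc1` gives 310 nM and compound 3 `C[C@H](CN1CCC(F)(F)CC1)NC(=O)c1ccc(-c2noc(C(F)(F)F)n2)cc1` gives 380 nM in this assay. Compound 4 is therefore expected to gain, with a step of an at least 16-fold lower number from compound 2 to compound 4 (1.22 log units; beyond the scatter), because compound 1 gives 310 nM with the trifluoromethyl present. The estimate for compound 4 is 3000 nM, within 500 nM to 30000 nM, though a limit remains possible.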

Compound 4, half-maximal inhibitory concentration: > 50000 nM
Compound 4 gave a limit, no number; the forecaster's own chance of this, stated with the estimate: 30%; middle value at least 16-fold (1.22 log units) from the limit.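

Among the compounds shown here, compound 2 and compound 4 both sit at a limit and give no number, so no step between them can be read: the limit of > 50000 nM in this assay, at which 2 of the 4 values shown sit. The compounds shown leave open whether 3-(trifluoromethyl)-1,2,4-oxadiazol-5-yl in place of 1,2,4-oxadiazol-3-yl changes inhibition at all in this dipropylamino amide.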